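Cyclohexanediol glycoside esters: a stereochemical turn in a cytotoxicity assay

This account rests on a few compounds, and the source may have more. Where it says the series, first, only, none or still open, it means among the compounds named here.

Measured compounds:
compound 1 `O=C(/C=C/c1ccc(O)cc1)O[C@H]1[C@H](O[C@@H]2CCCC[C@H]2O)O[C@H](CO)[C@@H](O)[C@@H]1O` — > 10000 nM
compound 2 `O=C(/C=C\c1ccc(O)cc1)O[C@H]1[C@H](O[C@@H]2CCCC[C@H]2O)O[C@H](CO)[C@@H](O)[C@@H]1O` — > 10000 nM

Compound 1 `O=C(/C=C/c1ccc(O)cc1)O[C@H]1[C@H](O[C@@H]2CCCC[C@H]2O)O[C@H](CO)[C@@H](O)[C@@H]1O` and compound 2 `O=C(/C=C\c1ccc(O)cc1)O[C@H]1[C@H](O[C@@H]2CCCC[C@H]2O)O[C@H](CO)[C@@H](O)[C@@H]1O` were both tested in a functional assay on SK-MEL-2 cells (Homo sapiens) for cytotoxicity, read by sulforhodamine B assay; on this read-out lower numbers stand for stronger inhibition and higher numbers for weaker inhibition. Compound 1 gives > 10000 nM, which is a limit of this assay and not a number. Compound 2 gives > 10000 nM, likewise a limit of this assay. The step from the first to the second is a step that the two limits leave unreadable from compound 1 to compound 2; the two structures share all atoms and bonds and differ only in configuration as drawn, the double bond being E in compound 1 and Z in compound 2.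

Compound 2 therefore stands only at a limit, with no numerical value to anchor it.

Compound 3 `O=C(/C=C/c1ccc(O)cc1)O[C@H]1[C@H](O[C@H]2CCCC[C@@H]2O)O[C@H](CO)[C@@H](O)[C@@H]1O` is the next member. Relative to compound 2 the difference is the two compounds have the same atoms and bonds and differ only in configuration as drawn: 3 of 8 stereo elements differ; a stereocentre at a saturated ring carbon is drawn R in compound 2 and S in compound 3; a stereocentre at a saturated ring carbon is drawn R in compound 2 and S in compound 3; a double bond is drawn Z in compound 2 and E in compound 3. Going by the values given here, no measured step bears on the two ring stereocentres, and the only measured step, from compound 1 to compound 2, is unreadable from the two limits. The estimate for compound 3 in this assay is therefore 15000 nM, between 5000 nM and 60000 nM, expected to sit most likely at a limit again, with the step that the limit leaves unreadable from compound 2 to compound 3 not readable beyond the scatter.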

Compound 3, half-maximal inhibitory concentration: > 10000 nM
Compound 3 was reported as a limit; the forecaster's own chance of this, stated with the estimate: 85%; the middle value is on the limit's open side.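

In this assay compound 3 gives > 10000 nM as a limit of the assay and not a number. No step among compound 1, compound 2 and compound 3 can be read, and the reason is this: the limit of > 10000 nM in this assay, at which 3 of the 3 values shown sit. In this assay the compounds shown leave open whether the double bond configuration or the configuration of the two ring stereocentres makes any difference.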